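This account rests on a few compounds, and the source may have more. Where it says the series, first, only, none or still open, it means among the compounds named here.

Measured compounds in a functional assay on the whole organism (strain Kunming) with Mus musculus as the target, with a stated time of 30 min; a lower number here means that less compound is needed, a higher number that more compound is needed for the effect:

compound 1 `CCCCCCSc1nnc(COc2ccc(NC(C)=O)cc2)o1` gives 20.9 mg/kg
compound 2 `CCCCCSc1nnc(COc2ccc3c(c2)CCC(=O)N3)o1` gives 8.9 mg/kg
compound 3 `O=C1CCc2cc(OCc3nnc(SCc4ccc(C(F)(F)F)cc4)o3)ccc2N1` gives 23.1 mg/kg

Compound 1 stands second highest of the three numbers. Its nearest neighbour is compound 3, whose value lies within the scatter of compound 1; compound 2 gives a lower number, beyond the scatter. Among the measured compounds shown here, the only single-point step measured so far, a 2.6-fold higher number from compound 2 to compound 3 (0.41 log units; beyond the scatter), concerns the group bound to the sulfur of the shared core and leaves the other end of the molecule untouched.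

Compound 4 `CCCCCCSc1nnc(COc2ccc(-n3cnnc3)cc2)o1` differs from compound 1 at that other end: 4H-1,2,4-triazol-4-yl in place of acetamido on an aromatic carbon. For the measured compounds named here, no measured step touches this position, and the substituent on the six-membered aromatic ring is not varied anywhere among compounds 1 to 3, so the available data give no direct guidance. Going by the values given here, the one measured step, a 2.6-fold higher number from compound 2 to compound 3 (0.41 log units; beyond the scatter), stayed modest although it swapped a butyl for a larger group; a swap of one small substituent for another is, by analogy only, expected to stay at or below that size. Compound 4 is therefore expected to land close to compound 1, with an expected step of a 1.0-fold lower number from compound 1 to compound 4 (0.02 log units; within the scatter) of no clear direction. The estimate for compound 4 in this assay is 20 mg/kg, with a range from 7 mg/kg to 60 mg/kg.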

Compound 4, dose for half-maximal effect: 26.6 mg/kg
The estimate for compound 4 lay 1.3-fold (0.12 log units) below the measured number; low and high end bracket the measured number.
By their numbers in this assay, from the lowest: compound 2; then compounds 1, 3 and 4 (each within the scatter of the next).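

In this assay, the aromatic carbon para to a large group now has its first measured step: with 4H-1,2,4-triazol-4-yl in place of acetamido, a 1.3-fold higher number from compound 1 to compound 4 (0.10 log units; within the scatter). This exchange is a substantial one in what is counted: a group with no ring, 1 hydrogen-bond donor and 1 hydrogen-bond acceptor gives way to a five-membered aromatic ring with 0 hydrogen-bond donors and 3 hydrogen-bond acceptors, and the number still does not move beyond the scatter, so for this pair the read-out does not separate the two groups. No measured property of either group is available to account for this outcome.

On these data alone, whether this position accepts other groups equally remains open, for instance a carboxylic acid, an amine or a longer chain on the same aromatic carbon, and a single pair cannot show whether the same holds with a different group on the sulfur. Compound 2 differs from compound 1 in more than one place, so the compounds shown do not assign its lower number to any one of those places.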